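Replacing nitro with bromo on compound 2

A few compounds are considered here, and "the series" means these few. Any claim that something is new, unique, unknown or untested is made for them only; others in the source may bear on it.

Values in a functional assay on T47D cells (Homo sapiens) for cytotoxicity, read by MTT assay, with a stated time of 96 h (a higher number here means a weaker inhibitor, a lower number a stronger inhibitor), for the two compounds measured so far
- compound 1 `Cn1c(-c2ccccc2)ccc1-c1ccc(C(=N)N)cc1` gives 2100 nM
- compound 2 `N=C(N)c1ccc(-c2ccc(-c3ccc([N+](=O)[O-])cc3)o2)cc1` gives 3800 nM

Within the data shown here, compound 2 (3800 nM) and compound 1 (2100 nM) lie within the usual scatter of each other, so these numbers do not rank compound 2 against its only neighbour. Compound 3 `N=C(N)c1ccc(-c2ccc(-c3ccc(Br)cc3)o2)cc1` has not yet been measured. It differs from compound 2 by having bromo in place of nitro on an aromatic carbon, para to a large group (bromo in place of nitro on an aromatic carbon). Among the measured compounds shown here, no measured pair of compounds differs in one place, so the data do not show the size of any single change, and this one has no precedent to go on. In this assay no step beyond the scatter is expected, and this expectation simply takes compound 2 at 3800 nM as its starting point. The expected size of the change is a small estimated step (a 1.3-fold lower number from compound 2 to compound 3 (0.10 log units; within the scatter)) that stays within the scatter. For compound 3 the estimated value is 3000 nM (expected range 1000 nM to 9000 nM).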

Compound 3, half-maximal inhibitory concentration: 2400 nM
Estimate against measurement, compound 3: 1.3-fold (0.10 log units) above; measured number inside the range.
By their numbers in this assay, from the lowest: compounds 1, 3 and 2 (each within the scatter of the next).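

In this assay, among these compounds, this pair gives the first reading of a single change on the shared core: a 1.6-fold lower number from compound 2 to compound 3 (0.20 log units; within the scatter), on an aromatic carbon of a six-membered aromatic ring of carbon only, para to a large group. Nitro, with 3 heavy atoms and 2 hydrogen-bond acceptors, and bromo, with 1 heavy atom and 0 hydrogen-bond acceptors, therefore cannot be told apart at this position, although the two groups differ in these counts. Nothing available gives a reason for this result.

The compounds shown leave open whether an amine, a carboxylic acid or a methoxy group at this same position would also fall within the scatter of compound 2 or would produce a step beyond it. A single pair also cannot show whether bromo in place of nitro would give a similar result on another core, so this reading applies only to the core shared by compound 2 and compound 3.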